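The source may hold more compounds than are shown below. What is called first, only, known or untested is meant among the compounds shown, and "the series" means these compounds.

In a functional assay on MCF7 cells (Homo sapiens) for antiproliferative activity, read by MTT assay, with a stated time of 48 h (a lower number here means a stronger inhibitor, a higher number a weaker inhibitor), compound 1 `N=C(N)N/N=C(/C=C/c1ccccc1)c1ccccc1` gives 17000 nM, compound 2 `Cc1ccc(/C=C/C(=N/NC(=N)N)c2ccccc2)cc1` gives 16000 nM and compound 3 `N=C(N)N/N=C(/C=C/c1cccc([N+](=O)[O-])c1)c1ccccc1` gives 6500 nM, the lowest of these three numbers. Compound 4 `COc1cccc(/C=C/C(=N/NC(=N)N)c2ccccc2)c1` is unmeasured and differs from compound 3 by methoxy in place of nitro on an aromatic carbon, with methoxy in place of nitro on an aromatic carbon. Among the compounds with values here, two measured steps bear on this. Adding nitro gave a 2.6-fold lower number from compound 1 to compound 3 (0.42 log units; beyond the scatter), a modest step, while adding methyl gave a 1.1-fold lower number from compound 1 to compound 2 (0.03 log units; within the scatter), within the scatter. Neither step tests methoxy directly, but losing nitro may well forfeit that modest gain. The expected change is a 2.2-fold higher number from compound 3 to compound 4 (0.33 log units; beyond the scatter), a modest step to a higher number. Compound 4 is estimated at 14000 nM, within an expected range of 6500 nM to 28000 nM.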

Compound 4, half-maximal inhibitory concentration: 13000 nM
Beside the measured number, compound 4's estimate is 1.1-fold (0.03 log units) above it; measured number inside the range.
By their numbers in this assay, from the lowest: compounds 3, 4, 2 and 1 (each within the scatter of the next, the first and the last beyond it).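

In this assay, methoxy on this aromatic carbon, meta to a large group, gives a 1.3-fold lower number from compound 1 to compound 4 (0.12 log units; within the scatter), so at this position it cannot be told apart from hydrogen. Replacing nitro with methoxy gives a 2.0-fold higher number from compound 3 to compound 4 (0.30 log units; within the scatter), so this change also stays within the scatter, and compound 4 cannot be separated from either neighbour. Nothing available explains these results. The compounds shown leave open whether an amine or a carboxylic acid on this carbon would move the number beyond the scatter. They also leave open whether nitro would match its step from hydrogen elsewhere on the ring.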